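The source may hold more compounds than are shown below. What is called first, only, known or untested is meant among the compounds shown, and "the series" means these compounds.

Measured compounds:
compound 1 `COc1cc(-c2cc(/C=C/C(=O)c3ccc(N)cc3)[nH]n2)cc(OC)c1OC`, 1010 nM
compound 2 `COc1ccc(-c2cc(/C=C/C(=O)c3cc(OC)c(OC)c(OC)c3)[nH]n2)cc1OC`, 1330 nM
compound 3 `COc1ccc(C(=O)/C=C/c2cc(-c3cc(OC)c(OC)c(OC)c3)n[nH]2)cc1`, 1290 nM

In a functional assay on MDA-MB-468 cells (Homo sapiens) for inhibition, read by sulforhodamine B assay, with a stated time of 48 h (a lower number here means a stronger inhibitor of growth, a higher number a weaker inhibitor of growth), the three numbers lie close together. Compound 3 stands second highest of the three; its nearest neighbour is compound 2, its furthest compound 1, and both gaps are within the scatter. For the measured compounds named here, the only step bearing on the aryl ketone end of the shared core is a 1.3-fold higher number from compound 1 to compound 3 (0.11 log units; within the scatter), which shows that exchanging one substituent on that ring for another leaves the number where it was.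

Compound 4 `COc1cc(-c2cc(/C=C/C(=O)c3ccc(F)c(F)c3)[nH]n2)cc(OC)c1OC` differs from compound 3 by 3,4-difluorophenyl in place of 4-methoxyphenyl on a carbonyl carbon. Going by the values given here, no measured pair here exchanges a methoxy for fluorine, so the expectation rests on the small step seen for compound 1 to compound 3 and on the narrow spread among compounds 1, 2 and 3 in this assay. Compound 4 is therefore expected to show no step beyond the scatter, that is a 1.0-fold higher number from compound 3 to compound 4 (0.00 log units; within the scatter). The estimate for compound 4 in this assay is 1300 nM, with a range from 500 nM to 3500 nM.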

Compound 4, concentration for 50% growth inhibition: 2220 nM
Compound 4: middle estimate off by 1.7-fold (0.23 log units), on the low side, within the range that was stated.
By their numbers in this assay, from the lowest: compounds 1, 3, 2 and 4 (each within the scatter of the next, the first and the last beyond it).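

In this assay, 3,4-difluorophenyl on the carbonyl carbon gives a 1.7-fold higher number from compound 3 to compound 4 (0.24 log units; within the scatter), so this exchange for 4-methoxyphenyl does not separate from the scatter. Against 4-aminophenyl, the same group gives a 2.2-fold higher number from compound 1 to compound 4 (0.34 log units; beyond the scatter), the first step in the series to pass the scatter, though only modestly. For the compounds shown here, the position is therefore not wholly insensitive to the group on the carbonyl carbon, but the change is small and is seen in only one of the two comparisons.

No supporting measurement accounts for this modest step. The compounds shown leave open how 4-fluorophenyl, with its single fluorine, or a phenyl ring bearing a carboxylic acid would stand at this position, and so whether both fluorines are involved in the step from the 4-aminophenyl compound.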